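From 3-chlorophenyl to 2-chloro-6-fluorophenyl in compound 4

A few compounds are considered here, and "the series" means these few. Any claim that something is new, unique, unknown or untested is made for them only; others in the source may bear on it.

In a functional assay (muscle tissue) with Cavia porcellus as the target (a lower number here means that less compound is needed, a higher number that more compound is needed for the effect), compound 2 (`COC(=O)C1=C(C)N=C(C)/C(=C(/O)OC)C1c1cccc(Cl)c1`) gives 15.9 nM. Compound 1 (`COC(=O)C1=C(C)N=C(C)/C(=C(\O)OC)C1c1ccccc1C#N`) gives the same number, 15.9 nM, and together they hold the highest number of the three measured compounds. Compound 3 (`C=Cc1ccccc1C1C(C(=O)OC)=C(C)N=C(C)/C1=C(\O)OC`) gives the lowest, 4.47 nM.

Compound 4 (`COC(=O)C1=C(C)N=C(C)/C(=C(/O)OC)C1c1c(F)cccc1Cl`) has not yet been measured. It differs from compound 2 in one place: 2-chloro-6-fluorophenyl in place of 3-chlorophenyl on a saturated ring carbon.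

Going by the values given here, no measured compound carries the 2-chloro-6-fluorophenyl group, so no measured step matches this change. The closest guide is a 3.6-fold lower number from compound 1 to compound 3 (0.55 log units; beyond the scatter), a different swap on the aromatic ring, which bears on the change only indirectly. It shows that a change there can shift the number by a modest amount. A modest shift toward a lower number in this assay is therefore expected, though the direction is only weakly supported. The expected change is a 2.3-fold lower number from compound 2 to compound 4 (0.36 log units; beyond the scatter). Compound 4 is estimated at 7 nM, with an expected range of 1.8 nM to 28 nM.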

Compound 4, half-maximal effective concentration: 7.59 nM
Estimate against measurement, compound 4: 1.1-fold (0.04 log units) below; the measured number falls inside the stated range.
By their numbers in this assay, from the lowest: compounds 3 and 4 (each within the scatter of the next); then compounds 1 and 2 (each within the scatter of the next).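

In this assay, replacing 3-chlorophenyl with 2-chloro-6-fluorophenyl on the saturated ring carbon gives a 2.1-fold lower number from compound 2 to compound 4 (0.32 log units; beyond the scatter). This is the first step shown in which a halogen-bearing phenyl group is exchanged for another, and it shows that changing the halogens on this ring alone can move the number beyond the scatter. No measurement offered here explains the shift.

The step changes the chlorine's place on the ring and adds fluorine at once, so the compounds shown do not separate the two contributions. From the compounds shown here alone, how a 2-chlorophenyl or 2-fluorophenyl group would compare at this position remains open, as does the outcome with an unsubstituted phenyl or a methoxyphenyl group.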